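The source may hold more compounds than are shown below. What is called first, only, known or untested is meant among the compounds shown, and "the series" means these compounds.

Compound 1 `CC[C@@H]1C(=O)N(C)c2cnc(-n3ccnc3-c3ccccc3)nc2N1C1CCCC1`: 0%
Compound 2 `CC[C@@H]1C(=O)N(C)c2cnc(-n3ccnc3-c3ccccc3)nc2N1CCC(F)(F)F`: 2%

These two compounds share a core and were tested in an ADME assay on microsomes from liver (Mus musculus) for metabolic stability, with a stated time of 30 min, tested at 1 uM; on this read-out higher numbers stand for a more stable compound and lower numbers for a less stable compound. Compound 2 gives 2% and cannot be told apart from compound 1, which gives 0%. Almost none of either compound is left at the end of the test, so both sit at the bottom of the scale.

Compound 3 `CC[C@@H]1C(=O)N(C)c2cnc(-n3ccnc3-c3ccccc3)nc2N1[C@H]1CCOC1` keeps the same core but carries oxolan-3-yl in place of 3,3,3-trifluoropropyl on a nitrogen on an aromatic ring in a ring.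

Going by the values given here, only one measured step bears on this change. It is a swap at the same nitrogen, from cyclopentyl to 3,3,3-trifluoropropyl, and it is a number 2 percentage points higher from compound 1 to compound 2 (within the scatter). Two quite different groups at this place have therefore given matching numbers. Among the compounds with values here, no measured compound has a ring with a hetero atom there, so the data cannot show what that adds. Only a small upward move is expected, with nothing clearly beyond the scatter. The estimated step is a number 3 percentage points higher from compound 2 to compound 3 (within the scatter). For compound 3 the expected value is 5%, with an estimated range of 0% to 18%.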

Compound 3, percent of the compound remaining: 51%
Compound 3: middle estimate off by 46 percentage points, on the low side; measured number above the stated range.
By their numbers in this assay, from the lowest: compounds 1 and 2 (each within the scatter of the next); then compound 3.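

The nitrogen that carries these groups turned out to matter a great deal in this assay: oxolan-3-yl in place of 3,3,3-trifluoropropyl gives a number 49 percentage points higher from compound 2 to compound 3 (beyond the scatter) and moves the series well off the bottom of the scale. The comparison with cyclopentyl is the sharper one, since both groups are five-membered non-aromatic rings and compound 3 has an oxygen as its one hetero atom, and this swap gives a number 51 percentage points higher from compound 1 to compound 3 (beyond the scatter) in the same test. A ring alone therefore did not lift the number in compound 1, and three fluorines on a chain did not lift it in compound 2, but the data offer no measured explanation for why the oxygen-bearing ring stands apart.

Going by these compounds alone, with only one compound carrying an oxygen at this nitrogen, it remains open whether the gain belongs to that atom, to its place in the ring, or to the defined stereocentre of oxolan-3-yl. Also unsettled is what the open chain 2-methoxyethyl, the six-membered ring oxan-4-yl or an amine such as pyrrolidin-3-yl would give here.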